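Methoxymethyl to hydroxymethyl on a diaryl chain core

This account rests on a few compounds, and the source may have more. Where it says the series, first, only, none or still open, it means among the compounds named here.

Measured compounds:
compound 1 `COc1cc(C(c2ccc(O)c(OC)c2)[C@H](C)[C@H](C)CO)ccc1O` — > 100000 nM
compound 2 `COc1ccc(C(c2ccc(OC)c(OC)c2)[C@@H](C)[C@H](C)CO)cc1OC` — > 100000 nM
compound 3 `COC[C@@H](C(C)C)C(c1ccc(O)c(OC)c1)c1ccc(O)c(OC)c1` — 54000 nM

In a functional assay on HL-60 cells (Homo sapiens) for cytotoxicity, read by WST assay, with a stated time of 48 h (on this read-out higher numbers stand for weaker inhibition and lower numbers for stronger inhibition), compound 1 reaches only a limit, > 100000 nM, and no number. Compound 2 likewise reaches only a limit in this assay, > 100000 nM. Among the compounds with values here, compound 3 is the one compound of the three that gives a number in this assay, 54000 nM, and so it stands as the single fixed point among the values shown.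

Compound 4 `COc1cc(C(c2ccc(O)c(OC)c2)[C@H](CO)C(C)C)ccc1O` differs from compound 3 in one place: 1-(hydroxymethyl)-2-methylpropyl in place of 1-(methoxymethyl)-2-methylpropyl on a saturated chain carbon bound to two aromatic carbons.

Within the data shown here, the only measured step that touches this position is an at least 1.8-fold lower number from compound 1 to compound 3 (0.26 log units; that floor lies within the scatter), a step whose floor lies within the scatter, so it shows little beyond the fact that compound 1 sits at the limit of > 100000 nM in this assay, at which 2 of the 3 values shown sit. The change from compound 3 to compound 4 brings back a hydroxymethyl group of the kind carried by compound 1, and two of three values shown are limits, so the expectation in this assay leans toward a weaker number, a 1.6-fold higher number from compound 3 to compound 4 (0.20 log units; within the scatter), with a real chance that only a limit is reported. Compound 4 is therefore estimated at 85000 nM, within 30000 nM to 250000 nM.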

Compound 4, half-maximal inhibitory concentration: > 100000 nM
Compound 4 gave a limit, no number (the forecaster's own chance of this, stated with the estimate: 50%); at least 1.1-fold (0.07 log units) between middle value and limit.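

In this assay, putting 1-(hydroxymethyl)-2-methylpropyl in place of 1-(methoxymethyl)-2-methylpropyl on a saturated chain carbon bound to two aromatic carbons gives an at least 1.8-fold higher number from compound 3 to compound 4 (0.26 log units; that floor lies within the scatter), so this pair compares the two groups directly on the same branched chain, and of the two only the methoxymethyl form yields a number. Compound 4 gives only a limit, not a number, and it joins the compounds that stop there: the limit of > 100000 nM in this assay, at which 3 of the 4 values shown sit. The step between compound 1 and compound 4 cannot be read, as both values are limits, so exchanging 2-(hydroxymethyl)-1-methylpropyl for 1-(hydroxymethyl)-2-methylpropyl shows nothing about the shape of the chain.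

The compounds shown leave open how far the hydroxymethyl compounds lie beyond the limit, and therefore how large the real gap to compound 3 is. They also leave open whether an ethoxymethyl group, an aminomethyl group or a carboxylic acid in this place would give a number, and how any of these would compare with the methoxymethyl group of compound 3.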